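The source may report more compounds than this note shows. Statements on the series, on what has been measured and on what is new or still open speak of the compounds shown alone.

Working notes on a series of esters of a shared core, each carrying a selenocyanate on a saturated chain of differing length. Compound 1 `COc1ccc(N(C)c2nc(C)nc3ccccc23)cc1C(=O)OCC[Se]C#N` gives 353 nM in a functional assay on A549 cells (Homo sapiens) for inhibition, read by MTT assay, with a stated time of 48 h; a higher number here means a weaker inhibitor, a lower number a stronger inhibitor. Compound 2 `COc1ccc(N(C)c2nc(C)nc3ccccc23)cc1C(=O)OCCC[Se]C#N` gives 250 nM in this assay, and compound 3 `COc1ccc(N(C)c2nc(C)nc3ccccc23)cc1C(=O)OCCCCCC[Se]C#N` gives 488 nM in this assay. Compound 3 differs from compound 2 in the chain: a group of 6 heavy atoms (4 carbon, 1 nitrogen, 1 selenium; no ring) in place of a group of 3 heavy atoms (1 carbon, 1 nitrogen, 1 selenium; no ring), on a saturated chain carbon, three bonds along the chain from an oxygen next to a carbonyl group. The step is a 2.0-fold higher number from compound 2 to compound 3 (0.29 log units; within the scatter); likewise a 1.4-fold higher number from compound 2 to compound 1 (0.15 log units; within the scatter) and a 1.4-fold higher number from compound 1 to compound 3 (0.14 log units; within the scatter). Across compound 1, compound 2 and compound 3, then, chain length produces no step that rises above the scatter.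

Compound 4 `COc1ccc(N(C)c2nc(C)nc3ccccc23)cc1C(=O)OCCCCC[Se]C#N` has not yet been measured in this assay. The change from compound 3 to compound 4 is a group of 3 heavy atoms (1 carbon, 1 nitrogen, 1 selenium; no ring) in place of a group of 4 heavy atoms (2 carbon, 1 nitrogen, 1 selenium; no ring), on a saturated chain carbon, five bonds along the chain from an oxygen next to a carbonyl group. The same kind of change occurs from compound 2 to compound 1: a group of 3 heavy atoms (1 carbon, 1 nitrogen, 1 selenium; no ring) in place of a group of 4 heavy atoms (2 carbon, 1 nitrogen, 1 selenium; no ring), on a saturated chain carbon, two bonds along the chain from an oxygen next to a carbonyl group. The two places are not identical: in the earlier pair the carbon is two bonds along the chain from an oxygen next to a carbonyl group, in the new pair five bonds along. The earlier step was a 1.4-fold higher number from compound 2 to compound 1 (0.15 log units; within the scatter). For compound 4 a step of similar size is expected, a 1.2-fold lower number from compound 3 to compound 4 (0.09 log units; within the scatter), resting on the step of a 1.4-fold higher number from compound 2 to compound 1 (0.15 log units; within the scatter) and on compound 3 with 488 nM. Compound 4 is expected to give about 400 nM in this assay, plausibly between 200 nM and 800 nM.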

Compound 4, half-maximal inhibitory concentration: 592 nM
Compound 4: middle estimate off by 1.5-fold (0.17 log units), on the low side; low and high end bracket the measured number.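

In this assay the new shortening of the chain, a 1.2-fold higher number from compound 3 to compound 4 (0.08 log units; within the scatter), agrees with the earlier shortening at the other chain length: the same change on two cores in this assay, a 1.4-fold higher number (0.15 log units; within the scatter) from compound 2 to compound 1 and a 1.2-fold higher number (0.08 log units; within the scatter) from compound 3 to compound 4, 1.2-fold (0.07 log units) apart, within the scatter of two such steps. The wider change in chain, a 1.7-fold higher number from compound 1 to compound 4 (0.22 log units; within the scatter), also agrees with its earlier counterpart: the same change on two cores in this assay, a 2.0-fold higher number (0.29 log units; within the scatter) from compound 2 to compound 3 and a 1.7-fold higher number (0.22 log units; within the scatter) from compound 1 to compound 4, 1.2-fold (0.07 log units) apart, within the scatter of two such steps. Among these compounds, these steps carry over within the scatter, but since each is itself within the scatter, this shows only that no change of size appears between the two places, not that chain length has a transferable effect; the one step beyond the scatter, a 2.4-fold higher number from compound 2 to compound 4 (0.37 log units; beyond the scatter), is modest and rests on a single pair, and it sets no trend along the series.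

All the compounds shown keep the shared core and a saturated unbranched chain ending in selenocyanate. Open, then, is whether a longer chain, a branched chain or an amine within the chain would give a step that stands clear of the scatter, and whether a thiocyanate in place of the selenocyanate would keep these values.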